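A few compounds are considered here, and "the series" means these few. Any claim that something is new, unique, unknown or untested is made for them only; others in the source may bear on it.

Measured compounds in a functional assay on PC-3 cells (Homo sapiens) for cytotoxicity, read by MTT assay, with a stated time of 72 h; on this read-out higher numbers stand for weaker inhibition and lower numbers for stronger inhibition:
- compound 1, `COc1cc(Nc2nc3ccccc3nc2S(=O)(=O)c2ccc(Br)cc2)cc(OC)c1`: 18200 nM
- compound 2, `O=S(=O)(c1ccc(Br)cc1)c1nc2ccccc2nc1Nc1ccc(F)cc1`: 9160 nM

For the measured compounds named here, compound 2 carries the lowest of the two numbers, but the only measured step, a 2.0-fold lower number from compound 1 to compound 2 (0.30 log units; within the scatter), lies within the scatter, so the two compounds are not separated on this read-out. Going by the values given here, that step exchanges the whole aryl group on the ring nitrogen and is the only comparison available.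

Compound 3, `O=S(=O)(c1ccc(Br)cc1)c1nc2ccccc2nc1Nc1ccc(Cl)cc1`, differs from compound 2 by chloro in place of fluoro on an aromatic carbon. Among the compounds with values here, no measured step bears directly on this exchange: the step from compound 1 to compound 2 changes the aryl pattern on the same nitrogen, not a halogen for a halogen, and its size is itself within the scatter. With nothing in the series pointing to a large effect of this change, the expected step of a 1.3-fold lower number from compound 2 to compound 3 (0.12 log units; within the scatter) is small, with a slight lean towards a lower number, and not clearly beyond the scatter. Compound 3 is therefore estimated at 7000 nM, with a range of 3000 nM to 16000 nM in this assay.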

Compound 3, half-maximal inhibitory concentration: 7460 nM
Estimate against measurement, compound 3: 1.1-fold (0.03 log units) below; low and high end bracket the measured number.
By their numbers in this assay, from the lowest: compounds 3, 2 and 1 (each within the scatter of the next, the first and the last beyond it).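

In this assay, for the compounds shown here, the exchange of fluoro for chloro on an aromatic carbon para to a large group gives a 1.2-fold lower number from compound 2 to compound 3 (0.09 log units; within the scatter) and so leaves the two halogens unseparated at this position, the first direct reading of a halogen-for-halogen change. The aryl exchange on the nitrogen now yields a step past the scatter, a 2.4-fold lower number from compound 1 to compound 3 (0.39 log units; beyond the scatter) for 4-chlorophenyl in place of 3,5-dimethoxyphenyl, though this step is modest and the matching step with 4-fluorophenyl, a 2.0-fold lower number from compound 1 to compound 2 (0.30 log units; within the scatter), stays within the scatter, so the reading rests on compound 3 alone and not on a shared halogen effect. No available data offer an explanation for either step.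

The compounds shown do not tell whether a methyl, a trifluoromethyl, a carboxylic acid or a dimethylamino group at this same place would stay as close to chloro and fluoro or would move the number beyond the scatter. They also leave open how much the 3,5-dimethoxy pattern and the bromo on the sulfonyl-bearing phenyl ring each contribute, as the shared core and that bromo are constant throughout.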